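Swapping the 4-chlorophenyl group of compound 1

A few compounds are considered here, and "the series" means these few. Any claim that something is new, unique, unknown or untested is made for them only; others in the source may bear on it.

In a functional assay on HeLa cells (Homo sapiens) for antiproliferative activity, read by MTT assay, with a stated time of 96 h (a higher number here means a weaker inhibitor, a lower number a stronger inhibitor), compound 1 `O=C1C2=C(C(=O)c3ncccc31)C1(CS2)NC(=O)N(c2ccc(Cl)cc2)C1=O` stands lowest of the two numbers at 2 nM against compound 2 `CCN(CC)c1ccc(N2C(=O)NC3(CSC4=C3C(=O)c3ncccc3C4=O)C2=O)cc1` at 50 nM in the same read-out. Compound 3 `O=C1C2=C(C(=O)c3ncccc31)C1(CS2)NC(=O)N(c2ccncc2)C1=O` is still unmeasured and carries pyridin-4-yl in place of 4-chlorophenyl on an amide-type nitrogen in a ring. Among the compounds with values here, the only measured step, diethylamino in place of chloro on an aromatic carbon, is large at a 25-fold higher number from compound 1 to compound 2 (1.40 log units; beyond the scatter) and is a different change. A smaller step toward a higher number is therefore expected in this assay and is estimated as a 5.0-fold higher number from compound 1 to compound 3 (0.70 log units; beyond the scatter) for this swap. Compound 3 is expected at 10 nM with an estimated range from 2 nM to 50 nM in this read-out.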

Compound 3, half-maximal inhibitory concentration: 10 nM
The estimate for compound 3 equals the measured number at the digits printed; low and high end bracket the measured number.
By their numbers in this assay, from the lowest: compound 1; then compound 3; then compound 2.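

In this assay, replacing 4-chlorophenyl with pyridin-4-yl on the amide-type nitrogen gives a 5.0-fold higher number from compound 1 to compound 3 (0.70 log units; beyond the scatter), so the number at this position responds to a change of the ring itself, not only to a change of the group on that ring. This modest step is smaller than the large earlier one, a 25-fold higher number from compound 1 to compound 2 (1.40 log units; beyond the scatter). No evidence here explains either step. The compounds shown leave open how pyridin-3-yl or pyridin-2-yl would compare with pyridin-4-yl. They also leave open whether fluoro or dimethylamino in place of chloro would give a smaller step.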